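Cyclopentyl amide in a quinolone series against colon cancer cells

The source may report more compounds than this note shows. Statements on the series, on what has been measured and on what is new or still open speak of the compounds shown alone.

Compound 3 `C#CCn1cc(C(=O)NC(CC(=O)Nc2ccccn2)c2ccccc2)c(=O)c2cc(F)c(Cl)nc21` is the strongest of the three measured analogues: in a functional assay on SW-620 cells (Homo sapiens) for cytotoxicity, read by MTT assay, with a stated time of 72 h (a higher number here means a weaker inhibitor, a lower number a stronger inhibitor), compound 3 gives 2300 nM, the lowest of the numbers shown. Compound 1 `C#CCn1cc(C(=O)NC(CC(=O)Nc2ccccc2)c2ccccc2)c(=O)c2cc(F)c(Cl)nc21`, the phenyl amide, gives 5700 nM in this assay. Compound 2 `C#CCn1cc(C(=O)NC(CC(=O)NC2CCCCC2)c2ccccc2)c(=O)c2cc(F)c(Cl)nc21`, the cyclohexyl amide, gives > 10000 nM, which is a limit of the assay rather than a number. That limit is the limit of > 10000 nM in this assay, at which 1 of the 3 values shown sits. The new compound 4 `C#CCn1cc(C(=O)NC(CC(=O)NC2CCCC2)c2ccccc2)c(=O)c2cc(F)c(Cl)nc21` differs from compound 3 by cyclopentyl in place of pyridin-2-yl on an amide-type nitrogen.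

The measured steps bearing on this are an at least 4.3-fold lower number from compound 2 to compound 3 (0.63 log units; beyond the scatter) and a 2.5-fold lower number from compound 1 to compound 3 (0.39 log units; beyond the scatter), both of which favour pyridin-2-yl over a carbocycle, and an at least 1.7-fold higher number from compound 1 to compound 2 (0.24 log units; that floor lies within the scatter), where the saturated ring gave the weaker result. Going the other way, from aromatic pyridin-2-yl to saturated cyclopentyl, the account therefore expects a higher number in this assay, a step of about a 3.9-fold higher number from compound 3 to compound 4 (0.59 log units; beyond the scatter). Compound 4 is thus estimated at 9000 nM, within a range of 4000 nM to 25000 nM, with a fair chance that only a limit is reported.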

Compound 4, half-maximal inhibitory concentration: 2100 nM
Compound 4: middle estimate off by 4.3-fold (0.63 log units), on the high side; the measured number lies below the stated range.
By their numbers in this assay, from the lowest: compounds 4 and 3 (each within the scatter of the next); then compound 1. At a limit, above all of these: compound 2.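

In this assay, a saturated ring on the amide-type nitrogen does not have to give the weaker result: with cyclopentyl there is a 1.1-fold lower number from compound 3 to compound 4 (0.04 log units; within the scatter), so the aromatic pyridin-2-yl, with its ring nitrogen, is not needed at this position to reach this level. Saturation alone therefore does not set the outcome, since the two saturated rings part with an at least 4.7-fold lower number from compound 2 to compound 4 (0.67 log units; beyond the scatter), and replacing phenyl with cyclopentyl gives a 2.7-fold lower number from compound 1 to compound 4 (0.43 log units; beyond the scatter). Compound 2 still stands at a limit and not at a number: the limit of > 10000 nM in this assay, at which 1 of the 4 values shown sits.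

The compounds shown leave open how cyclobutyl, or an open chain such as isopropyl, would compare with cyclopentyl on this nitrogen. Also open, on these data alone, is where a saturated ring holding a hetero atom, such as tetrahydropyran-4-yl, would fall.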